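The source may report more compounds than this note shows. Statements on the series, on what has been measured and on what is new or still open speak of the compounds shown alone.

Of the compounds shown here, three have been measured. Compound 1 `Cc1cc(C)c2c(O)cc(-c3cccc4ccccc34)nc2n1` gives 589 nM in a functional assay on SF-295 cells (Homo sapiens) for antiproliferative activity; a lower number here means a stronger inhibitor of growth, a higher number a weaker inhibitor of growth. Compound 2 `Cc1cccc(-c2cc(O)c3cc(C)cnc3n2)c1` gives 417 nM in this assay, a value within the usual scatter of that of compound 1, so the two cannot be told apart. Compound 3 `Cc1cc(C)c2c(O)cc(-c3ccc4ccccc4c3)nc2n1` gives 14800 nM in this assay, a far weaker result; the gap from compound 1 to compound 3 lies well beyond the scatter. Compound 1 thus stands among the stronger growth inhibitors measured here, with compound 3 the clear outlier.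

Compound 4 `Cc1ccnc2nc(-c3cccc4ccccc34)cc(O)c12` has not yet been measured. It differs from compound 1 in one place: hydrogen in place of methyl on an aromatic carbon. The change sits on an aromatic carbon next to the ring nitrogen of the shared core. Among the compounds with values here, no pair of measured compounds isolates this change, since compound 2 carries a different aryl group as well as a different core. The author expects only a modest step from compound 1 to compound 4, a 1.5-fold higher number from compound 1 to compound 4 (0.18 log units; within the scatter), toward somewhat weaker inhibition, possibly within the scatter. Compound 4 is accordingly estimated at 900 nM, with a range from 300 nM to 3000 nM.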

Compound 4, concentration for 50% growth inhibition: 10.7 nM
Estimate against measurement, compound 4: 84-fold (1.92 log units) above; measured number below the stated range.
By their numbers in this assay, from the lowest: compound 4; then compounds 2 and 1 (each within the scatter of the next); then compound 3.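

In this assay, hydrogen in place of methyl on this aromatic carbon, next to the ring nitrogen of the shared core, gives a 55-fold lower number from compound 1 to compound 4 (1.74 log units; beyond the scatter) and so moves toward much stronger growth inhibition. The earlier compounds shown here could not isolate this position, and this single pair now shows that it is far from silent: the loss of one methyl group, with the other methyl group and the aryl group unchanged, is enough to produce a large step. Nothing measured here explains the size of that step. 

From the compounds shown here alone, whether a larger group on this carbon, such as an ethyl chain, a methoxy group or a chlorine atom, would track with hydrogen or with methyl remains open. Also open, going by these compounds, is whether the same change would give a step of similar size with the aryl group of compound 3.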